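Adding a hydroxy group to compound 1

The source may report more compounds than this note shows. Statements on the series, on what has been measured and on what is new or still open speak of the compounds shown alone.

Measured in a functional assay on HCT-116 cells (Homo sapiens) for antiproliferative activity, read by MTT assay, with a stated time of 48 h; a higher number here means a weaker inhibitor, a lower number a stronger inhibitor:
compound 1 `COc1ccc(-c2c(Nc3cc(OC)c(OC)c(OC)c3)c3ccccc3oc2=O)cc1`: 63500 nM
compound 2 `COc1ccc(-c2c(Nc3ccc(NC(C)=O)cc3)c3ccccc3oc2=O)cc1`: "not determined" (no result reported)
compound 3 `COc1ccc(-c2c(Nc3cccc(C(F)(F)F)c3)c3ccc(OC)cc3oc2=O)cc1`: 41200 nM

The numbers for compound 1 and compound 3 lie within the usual scatter of each other, and compound 2 has no number to compare, so compound 1 has no clear rank. Compound 4 `COc1ccc(-c2c(Nc3cc(OC)c(OC)c(OC)c3)c3ccc(O)cc3oc2=O)cc1` keeps the core of compound 1 but has hydroxy in place of hydrogen on an aromatic carbon. Among the compounds with values here, no measured pair shows this change alone. Starting from compound 1 at 63500 nM, only a modest move toward a lower number is expected in this assay, possibly none beyond the scatter. The expected step is a 1.6-fold lower number from compound 1 to compound 4 (0.20 log units; within the scatter). For compound 4 the estimated value is 40000 nM, with an expected range from 15000 nM to 90000 nM.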

Compound 4, half-maximal inhibitory concentration: 64200 nM
Compound 4: middle estimate off by 1.6-fold (0.21 log units), on the low side; the measured number falls inside the stated range.
By their numbers in this assay, from the lowest: compounds 3, 1 and 4 (each within the scatter of the next).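

Within the data shown here, this is the first comparison here in which a single change can be read alone. In this assay, hydroxy in place of hydrogen on an aromatic carbon of the fused system of two rings gives a 1.0-fold higher number from compound 1 to compound 4 (0.00 log units; within the scatter) and so leaves the read-out within the scatter. At this position, then, adding one hydrogen-bond donor and one acceptor to the core of compound 1 produces no detectable difference in this assay.

From the compounds shown here alone, whether an amine or a carboxylic acid on the same carbon would also leave the number unmoved remains open. So does the outcome of hydroxy on a different carbon of that ring. No available measurement offers an explanation for this result.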